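Swapping the ring-nitrogen substituent in an isoxazole series

The source may hold more compounds than are shown below. What is called first, only, known or untested is meant among the compounds shown, and "the series" means these compounds.

Of the compounds shown here, three sharing one core have been measured in a functional assay on Huh-7 cells (Homo sapiens) for antiproliferative activity, read by sulforhodamine B assay, with a stated time of 72 h; on this read-out higher numbers stand for weaker inhibition and lower numbers for stronger inhibition. Compound 1 `Fc1ccccc1COc1ccc(-c2cc(CN3CCN(Cc4ccc(C(F)(F)F)cc4)CC3)no2)cc1` gives 1500 nM, compound 2 `COc1ccccc1COc1ccc(-c2cc(CN3CCN(Cc4ccc(C(F)(F)F)cc4)CC3)no2)cc1` gives 900 nM, and compound 3 `N#Cc1cccc(COc2ccc(-c3cc(CN4CCN(c5ccc(C(F)(F)F)cn5)CC4)no3)cc2)c1` gives 1700 nM. Among the measured compounds shown here, the only single-point step among them, a 1.7-fold lower number from compound 1 to compound 2 (0.22 log units; within the scatter), exchanges one substituent on an aromatic carbon and stays within the scatter. Compound 3 gives a number no lower than those of compound 1 and compound 2, yet both of its gaps to them are within the scatter, so the three cannot be ranked on this assay.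

Compound 4 `N#Cc1cccc(COc2ccc(-c3cc(CN4CCN(Cc5cccc(F)c5)CC4)no3)cc2)c1` differs from compound 3 in one place: 3-fluorobenzyl in place of 5-(trifluoromethyl)pyridin-2-yl on an amine nitrogen in a ring. For the measured compounds named here, no measured step bears directly on this exchange, since the single step recorded concerns an aromatic carbon elsewhere in the molecule and not the ring nitrogen; compounds 1 and 2, which carry a different group on that nitrogen, nevertheless give numbers within the scatter of compound 3. With no step beyond the scatter anywhere in this set, the change from compound 3 to compound 4 is expected to bring no shift beyond the scatter, a 1.2-fold lower number from compound 3 to compound 4 (0.08 log units; within the scatter). Compound 4 is therefore estimated at 1400 nM in this assay, with a range from 500 nM to 4000 nM.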

Compound 4, half-maximal inhibitory concentration: 2700 nM
Compound 4: the middle estimate sits 1.9-fold (0.29 log units) below what was measured; measured number inside the range.
By their numbers in this assay, from the lowest: compounds 2, 1, 3 and 4 (each within the scatter of the next, the first and the last beyond it).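

Among the compounds shown here, the exchange on the amine nitrogen in a ring gives a 1.6-fold higher number from compound 3 to compound 4 (0.20 log units; within the scatter) in this assay and is the first step in this set that can be read at that position. In this one pair, 5-(trifluoromethyl)pyridin-2-yl with its hydrogen-bond acceptor and 3-fluorobenzyl without one cannot be told apart on this read-out, although the two groups differ in heavy atoms and in the make-up of their aromatic rings. No other measurement accompanies this result to account for it.

Compound 3 and compound 4 form the only pair shown at this nitrogen, and both carry the same nitrile-bearing benzyl ether, so it stays open whether the same exchange would also stay within the scatter on a different aromatic substituent, such as the fluoro of compound 1 or the methoxy of compound 2. From the compounds shown here alone, it also stays open whether a more different group on this nitrogen, such as a plain hydrogen, an acetyl group, a longer phenethyl chain or a benzyl ring bearing a carboxylic acid, would move the number beyond the scatter.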